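The source may hold more compounds than are shown below. What is called first, only, known or untested is meant among the compounds shown, and "the series" means these compounds.

Compound 1 `COc1ccc(-n2cc(COc3ccc(/C=N/Nc4nc(-c5cc6cccc(OC)c6oc5=O)cs4)cc3)nn2)cc1` and compound 2 `COc1ccc(-n2cc(COc3ccc(/C=N/Nc4nc(-c5cc6ccccc6oc5=O)cs4)cc3)nn2)cc1` have been measured in an ADME assay on THP-1 cells (Homo sapiens) for cytotoxicity; on this read-out lower numbers stand for higher toxicity in this test and higher numbers for lower toxicity in this test. Within the data shown here, compound 1 gives 34500 nM, and compound 2 gives 36300 nM; the one recorded step, a 1.1-fold higher number from compound 1 to compound 2 (0.02 log units; within the scatter), leaves the two within the scatter of each other, so compound 1 stands at one of two numbers that cannot be told apart.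

Compound 3 `COc1ccc(-n2cc(COc3ccc(/C=N/Nc4nc(-c5cc6cc(Br)cc(OC)c6oc5=O)cs4)cc3)nn2)cc1` is not yet measured. It differs from compound 1 by bromo in place of hydrogen on an aromatic carbon. Among the measured compounds shown here, no measured step bears on this change: the only step in hand, a 1.1-fold higher number from compound 1 to compound 2 (0.02 log units; within the scatter), concerns a methoxy group and a different position, and it stayed within the scatter. Nothing therefore points to a shift beyond the scatter in either direction, and the expected step is a 1.0-fold lower number from compound 1 to compound 3 (0.01 log units; within the scatter).

On this basis compound 3 is estimated at 34000 nM in this assay, with a range from 15000 nM to 80000 nM.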

Compound 3, half-maximal cytotoxic concentration: 30300 nM
Estimate against measurement, compound 3: 1.1-fold (0.05 log units) above, within the range that was stated.
By their numbers in this assay, from the lowest: compounds 3, 1 and 2 (each within the scatter of the next).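

In this assay, among these compounds, bromo in place of hydrogen on an aromatic carbon, meta to a methoxy group and para to a fused ring, gives a 1.1-fold lower number from compound 1 to compound 3 (0.06 log units; within the scatter), the first reading at this position of the core of compound 1. Taken with a 1.1-fold higher number from compound 1 to compound 2 (0.02 log units; within the scatter), two single changes on this six-membered aromatic ring have now been read, and neither lies beyond the scatter. No available data bear on why this position responds as it does.

As far as these compounds go, whether an amine or a carboxylic acid at this position would also stay within the scatter remains open. Equally open, from the compounds shown here alone, is whether bromo would read the same on compound 2, which lacks the methoxy group, and whether a longer chain in place of that methoxy group would shift the number.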